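The compounds below may be only part of what the source reports. "The series", "measured", "known", "first", "only" and "open" are said of these compounds alone.

Measured compounds:
- compound 1 `O=C(Nc1ccc(Sc2nc3ccccc3s2)c(Cl)c1)c1cccc(Br)c1O` — 64000 nM
- compound 2 `O=C(Nc1ccccc1)c1cc(Br)cc(Br)c1` — > 100000 nM
- compound 3 `O=C(Nc1ccc(Sc2nc3ccccc3s2)cc1)c1cccc(Br)c1O` — 71000 nM

In an ADME assay on HEK293 cells (Homo sapiens) for cytotoxicity, read by reporter gene assay and resazurin assay, with a stated time of 48 h (a higher number here means that more compound is tolerated, a lower number that less compound is tolerated), compound 1 stands at the lowest of the two numbers given, with compound 3 as its nearest neighbour, and the difference a 1.1-fold higher number from compound 1 to compound 3 (0.05 log units; within the scatter) is no more than the scatter of the method. Compound 2 does not give a number but only a limit of the assay, (the limit of > 100000 nM in this assay, at which 1 of the 3 values shown sits).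

Compound 4 `O=C(Nc1ccc(Sc2nc3ccccc3s2)c(Cl)c1)c1cc(Br)cc(Br)c1` has not yet been measured. It differs from compound 1 by 3,5-dibromophenyl in place of 3-bromo-2-hydroxyphenyl on a carbonyl carbon. For the measured compounds named here, no measured step follows this particular change; the only measured step, from compound 1 to compound 3, concerns the other end of the molecule and is within the scatter. Compound 2 carries the same 3,5-dibromophenyl group on its carbonyl carbon, but it differs from compound 4 in more than one place, so it can guide only loosely. The step expected for compound 4 in this assay is therefore small, a 1.3-fold higher number from compound 1 to compound 4 (0.12 log units; within the scatter), leaning if anything toward a higher number, with a fair chance that only a limit is reported. Compound 4 is estimated at 85000 nM, in a range from 35000 nM to 200000 nM.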

Compound 4, half-maximal cytotoxic concentration: > 100000 nM
Compound 4: a limit, no number; the forecaster's own chance of this, stated with the estimate: 40%; middle value at least 1.1-fold (0.07 log units) from the limit.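

In this assay, for the compounds shown here, the exchange of 3-bromo-2-hydroxyphenyl for 3,5-dibromophenyl on a carbonyl carbon gives the first reading at this position, an at least 1.5-fold higher number from compound 1 to compound 4 (0.19 log units; that floor lies within the scatter), whereas the earlier step concerned only a chloro group elsewhere on the molecule. Only a floor is printed for this step, so it may be no larger than the scatter or may be much larger, and its true size cannot be read. Losing the hydroxy-bearing group, with its hydrogen-bond donor and acceptor, brought no lower number, and compound 4 gives only a limit of the assay, not a number: the limit of > 100000 nM in this assay, at which 2 of the 4 values shown sit.

The compounds shown do not separate the loss of the hydroxy group from the gain of the second bromine, so it remains open which of the two matters here, or whether either does. Also open, going by these compounds, are whether an amine or a carboxylic acid on this phenyl ring would give a number under the limit, and whether the chloro exchange would stay as small when 3,5-dibromophenyl sits on the carbonyl carbon.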